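Replacing cyano with 4-methylpiperazin-1-yl in the series

The source may report more compounds than this note shows. Statements on the series, on what has been measured and on what is new or still open speak of the compounds shown alone.

Measured so far in a functional assay on HepG2 cells (Homo sapiens) for inhibition, read by MTT assay, with a stated time of 72 h; a lower number here means a stronger inhibitor, a higher number a weaker inhibitor

compound 1 `CC(C)c1ccc(NC(=O)C2CCN(C/C=C/c3ccccc3)CC2)cc1` gives 12200 nM
compound 2 `CCCCc1ccc(NC(=O)C2CCN(C/C=C/c3ccccc3)CC2)cc1` gives 4320 nM
compound 3 `N#Cc1ccc(NC(=O)C2CCN(C/C=C/c3ccccc3)CC2)cc1` gives 38300 nM

Compound 3 stands highest of the three (38300 nM) and is so far the weakest inhibitor in this assay among these compounds. Compound 4 `CN1CCN(c2ccc(NC(=O)C3CCN(C/C=C/c4ccccc4)CC3)cc2)CC1` differs from it at one place (4-methylpiperazin-1-yl in place of cyano on an aromatic carbon), with 4-methylpiperazin-1-yl in place of cyano on an aromatic carbon, para to a large group.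

For the measured compounds named here, two measured steps bear most directly on this change, both modest and beyond the scatter: cyano in place of isopropyl (a 3.1-fold higher number from compound 1 to compound 3 (0.50 log units; beyond the scatter)) and cyano in place of butyl (an 8.9-fold higher number from compound 2 to compound 3 (0.95 log units; beyond the scatter)). Butyl in place of isopropyl (a 2.8-fold lower number from compound 1 to compound 2 (0.45 log units; beyond the scatter)) shows that the number also moves between the two non-cyano groups. Among these three compounds, cyano goes with the highest number, and none goes against that. Going by the values given here, no measured compound carries a ring at this place, so the size of the step is uncertain. With compound 1 (12200 nM) and compound 2 (4320 nM) both lower than compound 3, a modest fall in the number is expected when cyano leaves.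

The expected step is a 2.7-fold lower number from compound 3 to compound 4 (0.44 log units; beyond the scatter) in this assay on this estimate.

For compound 4 the estimated value is 14000 nM with an expected range from 4000 nM to 40000 nM in this series.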

Compound 4, half-maximal inhibitory concentration: 35200 nM
Estimate against measurement, compound 4: 2.5-fold (0.40 log units) below, and the stated range covers the measured number.
By their numbers in this assay, from the lowest: compound 2; then compound 1; then compounds 4 and 3 (each within the scatter of the next).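

Replacing cyano with 4-methylpiperazin-1-yl gives a 1.1-fold lower number from compound 3 to compound 4 (0.04 log units; within the scatter) in this assay, so at this place on the aromatic ring, a larger group with a six-membered non-aromatic ring and more heavy atoms reads the same as cyano within the scatter. Cyano therefore no longer stands alone at the high end: the new group gives an 8.1-fold higher number from compound 2 to compound 4 (0.91 log units; beyond the scatter) against butyl and a 2.9-fold higher number from compound 1 to compound 4 (0.46 log units; beyond the scatter) against isopropyl, and none of the four compounds goes against this split between the two alkyl groups and the two others. Nothing shown here accounts for cyano and 4-methylpiperazin-1-yl reading alike or for the alkyl groups reading lower.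

The compounds shown leave open whether the lower numbers extend to a longer chain than butyl, or whether they depend on the chain form, since isopropyl and butyl are the only alkyl groups at this place. They also leave open how a ring of carbon only, such as cyclohexyl, or a morpholine ring would read here, and so whether the nitrogen atoms of the piperazine ring matter to the number.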